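Swapping in a trichloromethyl group on compound 2

This account rests on a few compounds, and the source may have more. Where it says the series, first, only, none or still open, it means among the compounds named here.

In an ADME assay on stomach for pharmacokinetics, in simulated gastric fluid (a lower number here means that the compound disappears faster, a higher number that the compound lasts longer), compound 1 (`CCOc1cc(NC(=O)C2(NC(=O)c3ccc4c(C5CCCC5)c(-c5ncc(Cl)cn5)n(C)c4c3)CCC2)ccc1/C=C/C(=O)N[C@@H](CC(=O)O)C(N)=O`) gives > 5 h as a limit, not a number
Compound 2 (`CCOc1cc(NC(=O)C2(NC(=O)c3ccc4c(C5CCCC5)c(-c5ncc(Cl)cn5)n(C)c4c3)CCC2)ccc1/C=C/C(=O)OCOP(=O)(O)O`) gives 1.3 h as a measured half-life

Among the measured compounds shown here, compound 2 holds the only actual number so far, and the one measured step, an at least 3.8-fold lower number from compound 1 to compound 2 (0.58 log units; beyond the scatter), leaves it the lower of the two. Compound 3 (`CCOc1cc(NC(=O)C2(NC(=O)c3ccc4c(C5CCCC5)c(-c5ncc(Cl)cn5)n(C)c4c3)CCC2)ccc1/C=C/C(=O)OCC(Cl)(Cl)Cl`) differs from compound 2 on a saturated chain carbon bound to an oxygen next to a carbonyl group, where trichloromethyl enters (a group of 4 heavy atoms (1 carbon, 3 chlorine; no ring) in place of a group of 5 heavy atoms (4 oxygen, 1 phosphorus; no ring), on a saturated chain carbon bound to an oxygen next to a carbonyl group). For the measured compounds named here, no measured step covers this exchange directly. The nearest is an at least 3.8-fold lower number from compound 1 to compound 2 (0.58 log units; beyond the scatter), which brought in the phosphorus-bearing group that now leaves. With compound 2 at 1.3 h as the reference, a rise of similar size is expected rather than a further fall. The expected change is a 3.5-fold higher number from compound 2 to compound 3 (0.54 log units; beyond the scatter), an estimate only. Given (the limit of > 5 h in this assay, at which 1 of the 2 values shown sits), compound 3 may be reported only as a limit. In this assay the estimate for compound 3 is 4.5 h, expected within 2 h to 10 h, and still unmeasured.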

Compound 3, half-life: 1.75 h
Estimate against measurement, compound 3: 2.6-fold (0.41 log units) above; the measured number lies below the stated range.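

In this assay the exchange of the phosphorus-bearing group for trichloromethyl, on a saturated chain carbon bound to an oxygen next to a carbonyl group, gives a 1.3-fold higher number from compound 2 to compound 3 (0.13 log units; within the scatter) and so leaves the two compounds indistinguishable. Among the compounds shown here, at this place, two very different groups therefore give the same reading, which the earlier compounds could not show. With 2,2,2-trichloroethoxy on the carbonyl carbon the comparison with the amide gives an at least 2.8-fold lower number from compound 1 to compound 3 (0.45 log units; beyond the scatter) and so joins the step to compound 2 in staying beyond the scatter, though the value of compound 1 is a limit and bounds this step on one side only: the limit of > 5 h in this assay, at which 1 of the 3 values shown sits.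

The compounds shown leave open whether an amine or a plain ethyl chain at this place would read the same. They also leave open how much of the difference from compound 1 rests on the oxygen on the carbonyl carbon and how much on the rest of the group.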